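Amide nitrogen substituent exchange toward compound 3

The compounds below may be only part of what the source reports. "The series", "measured", "known", "first", "only" and "open" are said of these compounds alone.

Compound 1 `CC[C@@H](C)[C@H](NC(=O)c1ccc(C(CC)(CC)c2ccc(OCC(=O)C(C)(C)C)c(C)c2)n1CC)C(=O)OC` and compound 2 `CCn1c(C(=O)N(C)c2ccccc2)ccc1C(CC)(CC)c1ccc(OCC(=O)C(C)(C)C)c(C)c1` share one core and differ only at the amide. In an assay on HL-60 cells for agonist activity at vitamin D3 receptor (Homo sapiens), read by microscopy, with a stated time of 96 h (a higher number here means that more compound is needed for the effect, a lower number that less compound is needed), compound 1 gives 590 nM, and in the same assay compound 2 gives 18500 nM. Compound 2 stands at the higher of the two numbers; the step of a 31-fold higher number from compound 1 to compound 2 (1.50 log units; beyond the scatter) is the only measured one in the set. Compound 3 `CCn1c(C(=O)N(C)CC(=O)O)ccc1C(CC)(CC)c1ccc(OCC(=O)C(C)(C)C)c(C)c1` is not yet measured. It differs from compound 2 as follows: carboxymethyl in place of phenyl on an amide-type nitrogen. Among the compounds with values here, the one measured step bears on it only loosely, since it exchanged the whole substituent on the amide nitrogen rather than a single group on that nitrogen. Within the data shown here, no measured compound carries a carboxymethyl group, so the direction rests on a weak footing. For compound 3 the expected step is a 2.3-fold lower number from compound 2 to compound 3 (0.36 log units; beyond the scatter), leaning toward a somewhat lower number than compound 2. The estimate for compound 3 in this assay is 8000 nM, with a range from 2000 nM to 30000 nM.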

Compound 3, half-maximal effective concentration: 1390 nM
The estimate for compound 3 lay 5.8-fold (0.76 log units) above the measured number, and the stated range ends above it.
By their numbers in this assay, from the lowest: compound 1; then compound 3; then compound 2.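

Working notes on the amide nitrogen: in this assay, the methyl group stays in place while carboxymethyl replaces phenyl (a 13-fold lower number from compound 2 to compound 3 (1.12 log units; beyond the scatter)), so the high number of compound 2 does not follow from methyl substitution on this nitrogen alone. The remaining difference is much smaller (a 2.4-fold higher number from compound 1 to compound 3 (0.37 log units; beyond the scatter)), showing that the (1-(methoxycarbonyl)-2-methylbutyl)amino group is not required for a number in this range. Nothing available explains either step.

Still open, from the compounds shown here alone, is whether the lower number depends on the carboxylic acid in the entering group or simply on the removal of phenyl, a question that a plain ethyl group or a primary amide chain on this nitrogen would address. Going by these compounds, the effect of a longer chain ending in a carboxylic acid also remains open.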